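Methyl to fluoro at the limit of the assay

The compounds below may be only part of what the source reports. "The series", "measured", "known", "first", "only" and "open" are said of these compounds alone.

In a functional assay on ECV-304 cells (Homo sapiens) for cytotoxicity (a higher number here means a weaker inhibitor, a lower number a stronger inhibitor), compound 1 `Cc1ccc(S(=O)(=O)NN2C(=S)S/C(=C\c3ccc(Cl)c(Cl)c3)C2O)cc1` gives > 50000 nM, which is a limit of the assay and not a number. Compound 2 `O=C1/C(=C/c2ccc(F)cc2F)SC(=S)N1NS(=O)(=O)c1ccccc1` gives > 50000 nM, which is also a limit. Compound 3 `O=C1/C(=C/c2cc(F)c(F)cc2F)SC(=S)N1NS(=O)(=O)c1ccccc1` gives > 50000 nM, again a limit. Going by the values given here, the whole picture so far is the limit of > 50000 nM in this assay, at which 3 of the 3 values shown sit, so no compound here has yet produced a true number.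

Compound 4 `O=S(=O)(NN1C(=S)S/C(=C\c2ccc(Cl)c(Cl)c2)C1O)c1ccc(F)cc1` departs from compound 1 in one place, with fluoro in place of methyl on an aromatic carbon. The same difference can be read as 4-methylphenyl to 4-fluorophenyl.

Among the compounds with values here, only one measured step comes close to this change, and it is a step that the two limits leave unreadable from compound 2 to compound 3. That step puts fluoro in place of hydrogen, which is not the same swap, and it has no readable size. It therefore offers no size to carry over, and no change beyond the usual scatter is expected in this assay. This expectation rests on compound 1 and its limit of > 50000 nM.

The expected result is a number no higher from compound 1 to compound 4 (the limit leaves the size open). The assay will most likely report only a limit again. For compound 4 the estimate is 50000 nM, with an expected range from 20000 nM to 100000 nM.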

Compound 4, half-maximal inhibitory concentration: > 50000 nM
Compound 4: no number, only a limit; the forecaster's own chance of this, stated with the estimate: 85%; the middle value lies on the limit itself.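

Compound 1 and compound 4 both stop at a limit in this assay and give no number, so no size can be read for the change from methyl to fluoro. The same holds across the whole set: the limit of > 50000 nM in this assay, at which 4 of the 4 values shown sit.

The compounds shown leave open what true values any of them would give in this assay, and how far apart those values would lie.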